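Cyano to Methylsulfanyl: Estimating an Untested Compound 4

A few compounds are considered here, and "the series" means these few. Any claim that something is new, unique, unknown or untested is made for them only; others in the source may bear on it.

Compound 1, `O=C1C=C(Nc2ccc(F)cc2)CCC1`: in an assay on isolated protein for inhibition of cytochrome c oxidase subunit 2 (Homo sapiens), read by ELISA, with a stated time of 2 min, tested at 10 uM (on this read-out lower numbers stand for less inhibition and higher numbers for more inhibition at the one concentration tested (going by the name of the read-out)), compound 1 gives 55.6%.
Compound 2, `O=C1C=C(Nc2ccc([N+](=O)[O-])cc2)CCC1`: compound 2 gives 24.2%.
Compound 3, `N#Cc1ccc(NC2=CC(=O)CCC2)cc1`: compound 3 gives 47.1%.

All three share one core and differ only in the group on one aromatic carbon. Compound 3 stands second highest of the three numbers. Its nearest neighbour is compound 1, and the step of a number 8.5 percentage points lower from compound 1 to compound 3 (within the scatter) lies within the scatter, so these two cannot be ordered. Its furthest is compound 2, and the step of a number 22.9 percentage points higher from compound 2 to compound 3 (beyond the scatter) lies beyond the scatter.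

Compound 4, `CSc1ccc(NC2=CC(=O)CCC2)cc1`, is not yet measured. (methylsulfanyl in place of cyano on an aromatic carbon). Among the measured compounds shown here, the steps that bear on this are the other exchanges at the same aromatic carbon: a number 8.5 percentage points lower from compound 1 to compound 3 (within the scatter), a number 22.9 percentage points higher from compound 2 to compound 3 (beyond the scatter) and a number 31.4 percentage points lower from compound 1 to compound 2 (beyond the scatter). For the measured compounds named here, no measured compound carries methylsulfanyl, so there is no direct guide; exchanges at this carbon have ranged from a step within the scatter to a large one. Compound 4 is therefore estimated at 45%, with a range from 25% to 65%. For compound 4 this means an expected step of a number 2.1 percentage points lower from compound 3 to compound 4 (within the scatter), not beyond the scatter.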

Compound 4, a percentage reported as inhibition, at one concentration (the size of the read-out at that concentration, not a potency): 27.8%
Estimate against measurement, compound 4: 17.2 percentage points above; the range from low to high includes it.
By their numbers in this assay, from the lowest: compounds 2 and 4 (each within the scatter of the next); then compounds 3 and 1 (each within the scatter of the next).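

In this assay, the exchange of cyano for methylsulfanyl gives a number 19.3 percentage points lower from compound 3 to compound 4 (beyond the scatter), so this aromatic carbon responds clearly even to a group that matches cyano in heavy atoms and in hydrogen-bond donors and acceptors. Methylsulfanyl also gives a number 27.8 percentage points lower from compound 1 to compound 4 (beyond the scatter), whereas the comparison with nitro gives a number 3.6 percentage points higher from compound 2 to compound 4 (within the scatter), so methylsulfanyl and nitro cannot be ordered. The four groups now fall into two pairs, with nitro and methylsulfanyl forming a lower pair, clearly separated from an upper pair of fluoro and cyano, a split that the three earlier compounds could not show.

Nothing measured here accounts for this split. On these data alone, whether an amine, a carboxylic acid or a longer chain such as ethylsulfanyl at this carbon would join either pair or fall outside both remains open.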